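Hydroxyl stereocentre inversion in the cyclohexylamine series

This account rests on a few compounds, and the source may have more. Where it says the series, first, only, none or still open, it means among the compounds named here.

Measured so far:
compound 1 `CO[C@H]1CC[C@@H](Nc2cc(NCc3cnccc3C(F)(F)F)ncc2C#N)CC1` — 58 nM
compound 2 `CC1(C)C[C@@H](Nc2cc(NCc3cnccc3C(F)(F)F)ncc2C#N)CC[C@H]1O` — 120 nM

In an assay on isolated protein for inhibition of protein kinase C theta type (Homo sapiens), read by TR-FRET, with a stated time of 2 h (a lower number here means a stronger inhibitor, a higher number a weaker inhibitor), compound 2 gives 120 nM, the higher of the two numbers; its nearest neighbour is compound 1, and the step of a 2.1-fold higher number from compound 1 to compound 2 (0.32 log units; beyond the scatter) is the only one measured in the series, arising from 4-hydroxy-3,3-dimethylcyclohexyl in place of 4-methoxycyclohexyl on the ring nitrogen.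

Compound 3 `CC1(C)C[C@@H](Nc2cc(NCc3cnccc3C(F)(F)F)ncc2C#N)CC[C@@H]1O` is the next point. Against compound 2 the change is the two compounds have the same atoms and bonds and differ only in configuration as drawn: 1 of 2 stereo elements differ; a stereocentre at a saturated ring carbon is drawn R in compound 2 and S in compound 3, so the ring substituent itself is unchanged and only the drawn configuration at the carbon bearing the hydroxyl is reversed. Within the data shown here, no measured step speaks to such an inversion: the single step from compound 1 to compound 2 concerns a different substituent, not configuration. With nothing to anchor a direction, compound 3 is expected to sit within scatter of compound 2, the expected step being no change at the digits printed from compound 2 to compound 3 (within the scatter). The estimate for compound 3 in this assay is 120 nM, expected to fall between 45 nM and 320 nM.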

Compound 3, half-maximal inhibitory concentration: 120 nM
Beside the measured number, compound 3's estimate shows no gap at the digits printed; measured number inside the range.
By their numbers in this assay, from the lowest: compound 1; then compounds 2 and 3 (each within the scatter of the next).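

In this assay, inverting this saturated ring carbon gives no change at the digits printed from compound 2 to compound 3 (within the scatter), so the drawn R and S forms of the 4-hydroxy-3,3-dimethylcyclohexyl group cannot be told apart in this assay. Replacing 4-methoxycyclohexyl with the S form gives a 2.1-fold higher number from compound 1 to compound 3 (0.32 log units; beyond the scatter), the same size as the step to the R form, so the loss seen earlier holds for either configuration. The pair tests configuration alone: the fact that compounds 2 and 3 differ only in the configuration as drawn

The hydroxyl and the dimethyl enter together in the step from 4-methoxycyclohexyl, and the compounds shown do not separate their contributions. From the compounds shown here alone, it also remains open whether configuration at this carbon would still leave the number unmoved with an amine or a carboxylic acid in place of the hydroxyl.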